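Trifluoromethyl chromene esters: triazole nitrogen substituent swap

The compounds below may be only part of what the source reports. "The series", "measured", "known", "first", "only" and "open" are said of these compounds alone.

Measured so far:
- compound 1, `CCOC(=O)C1=Cc2ccccc2OC1(OCc1cn(-c2ccc(C)cc2)nn1)C(F)(F)F`: 30200 nM
- compound 2, `CCOC(=O)C1=Cc2ccccc2OC1(OCc1cc(-c2ccc3ccccc3c2)no1)C(F)(F)F`: 71800 nM

Two compounds of the shared core have numbers in a functional assay on DU-145 cells (Homo sapiens) for inhibition, read by MTT assay, with a stated time of 24 h; a lower number here means a stronger inhibitor, a higher number a weaker inhibitor. Compound 1 gives 30200 nM and stands at the lowest of the two numbers; compound 2 gives 71800 nM, a higher number beyond the scatter. For the measured compounds named here, only two compounds have been measured, so no step between compounds differing in one place can be drawn from them.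

Compound 3, `CCCCCCCCn1cc(COC2(C(F)(F)F)Oc3ccccc3C=C2C(=O)OCC)nn1`, is to be measured in this assay. It differs from compound 1 in one place: octyl in place of 4-methylphenyl on an aromatic nitrogen. Compound 2 carries a different five-membered ring and a different aromatic group, so its value gives no guide to what an octyl on the ring nitrogen does. Going by the values given here, with no measured step of this kind, the expectation is a change no larger than the scatter in either direction, with a wide range kept because the change is untested. Compound 3 is expected to give 35000 nM (range 12000 nM to 100000 nM). That estimate amounts to a step of a 1.2-fold higher number from compound 1 to compound 3 (0.06 log units; within the scatter), expected to sit within the usual scatter.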

Compound 3, half-maximal inhibitory concentration: > 150000 nM
Compound 3 gave a limit, no number; the forecaster's own chance of this, stated with the estimate: 25%; middle value at least 4.2-fold (0.63 log units) from the limit.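

In this assay compound 3 gives > 150000 nM, which is a limit of the assay and not a number. Octyl in place of 4-methylphenyl on an aromatic nitrogen of the five-membered aromatic ring with 3 nitrogen is the first change in the series that can be read at a single place, and it gives an at least 4.9-fold higher number from compound 1 to compound 3 (0.69 log units; beyond the scatter), so the group on this nitrogen is not interchangeable in this assay. Neither group carries a hydrogen-bond donor, a hydrogen-bond acceptor or a net charge, so these counts do not separate them, and the plain difference left in the structures is a six-membered aromatic ring leaving and a chain with no ring entering.

On these data alone, the step is a bound, and how far compound 3 lies from compound 1 stays open: the limit of > 150000 nM in this assay, at which 1 of the 3 values shown sits. Also open is whether the weaker result follows the absence of the aromatic ring or the length of the chain, a question that a cyclohexyl, a benzyl or a shorter chain such as butyl on the same nitrogen would help to separate.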